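Hydroxypiperidinyl sulfonamide variation in the shared urea series

The compounds below may be only part of what the source reports. "The series", "measured", "known", "first", "only" and "open" are said of these compounds alone.

Measured so far in an assay on isolated protein for inhibition of Nicotinamide phosphoribosyltransferase (Homo sapiens), read by mass spectrometry, with stated times of 15 min and 30 min; a lower number here means a stronger inhibitor, a higher number a weaker inhibitor:
compound 1 `O=C(NCc1ccc(S(=O)(=O)c2cncc(C(F)(F)F)c2)cc1)N1Cc2ccncc2C1` — 15 nM
compound 2 `CCC(=O)N1CCC(S(=O)(=O)c2ccc(CNC(=O)N3Cc4ccncc4C3)cc2)CC1` — 27 nM
compound 3 `O=C(NCc1ccc(S(=O)(=O)N2CCC(O)CC2)cc1)N1Cc2ccncc2C1` — 44 nM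

Compound 3 sits at the high end of the three numbers: the step from compound 1 to compound 3 is a 2.9-fold higher number from compound 1 to compound 3 (0.47 log units; beyond the scatter), while the step from compound 2 to compound 3 is a 1.6-fold higher number from compound 2 to compound 3 (0.21 log units; within the scatter). Compound 4 `O=C(NCc1ccc(S(=O)(=O)N2CCC[C@H](O)C2)cc1)N1Cc2ccncc2C1` differs from compound 3 by 3-hydroxypiperidin-1-yl in place of 4-hydroxypiperidin-1-yl on a sulfonyl sulfur. Among the measured compounds shown here, no measured step moves the hydroxyl within the ring; the steps that exchange the whole group on the sulfonyl sulfur, a 1.8-fold higher number from compound 1 to compound 2 (0.26 log units; within the scatter) and a 2.9-fold higher number from compound 1 to compound 3 (0.47 log units; beyond the scatter), are small to modest, so the present change is expected to give no step beyond the scatter, a 1.1-fold higher number from compound 3 to compound 4 (0.06 log units; within the scatter). Compound 4 is therefore estimated at 50 nM, with a range of 20 nM to 130 nM.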

Compound 4, half-maximal inhibitory concentration: 770 nM
For compound 4 the middle estimate is 15-fold (1.19 log units) below the measured one; measured number above the stated range.
By their numbers in this assay, from the lowest: compounds 1, 2 and 3 (each within the scatter of the next, the first and the last beyond it); then compound 4.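

In this assay, the sulfonyl sulfur substituent proves sensitive to where the hydroxyl sits on the piperidine ring: 3-hydroxypiperidin-1-yl in place of 4-hydroxypiperidin-1-yl gives an 18-fold higher number from compound 3 to compound 4 (1.24 log units; beyond the scatter). The other exchanges are also large, at a 29-fold higher number from compound 2 to compound 4 (1.46 log units; beyond the scatter) and a 51-fold higher number from compound 1 to compound 4 (1.71 log units; beyond the scatter), unlike the small to modest steps among compounds 1, 2 and 3. Nothing available explains this loss.

Compound 4 carries one defined stereocentre, so the contributions of hydroxyl placement and stereochemistry remain unseparated. Also open, as far as these compounds go, is whether the opposite 3-hydroxypiperidin-1-yl stereoisomer or a 3-aminopiperidin-1-yl group would behave like compound 4.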